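Carbamoyl to methoxymethyl on the chain of compound 3

A few compounds are considered here, and "the series" means these few. Any claim that something is new, unique, unknown or untested is made for them only; others in the source may bear on it.

Compound 3 `CCCn1c(=O)n(C)c(=O)c2c1ncn2CC(N)=O` is the weakest-placed of the three measured compounds in an assay on Cerebral cortex for binding affinity to adenosine receptor A1 (Cavia porcellus), read by radioligand binding; on this read-out lower numbers stand for stronger inhibition and higher numbers for weaker inhibition. In this assay compound 3 returns only > 200000 nM, which is a limit of the assay and not a number (the limit of > 200000 nM in this assay, at which 1 of the 3 values shown sits). Compound 4 `CCCn1c(=O)n(C)c(=O)c2c1ncn2CCOC` differs from compound 3 in a single place: methoxymethyl in place of carbamoyl on a saturated chain carbon bound to an aromatic nitrogen. Going by the values given here, no measured step touches this particular exchange. The only measured step among the compounds shown concerns a different chain: compound 1 `CCCn1c(=O)n(CCC#N)c(=O)c2[nH]cnc21` gives 15900 nM in this assay, compound 2 `CCCn1c(=O)n(CC(C)=O)c(=O)c2[nH]cnc21` gives 11400 nM, and the step of a 1.4-fold lower number from compound 1 to compound 2 (0.14 log units; within the scatter) shows that swapping one small polar group for another on a saturated chain carbon bound to an aromatic nitrogen moved the number hardly at all. On that basis the change from carbamoyl to methoxymethyl is expected to leave compound 4 in the same weak region, and compound 4 is estimated at 150000 nM, between 40000 nM and 400000 nM. This estimate means a step of an at least 1.3-fold lower number from compound 3 to compound 4 (0.12 log units; that floor lies within the scatter), which is expected to be no more than a modest drift from the limit seen for compound 3, with a real chance that only a limit is reported again.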

Compound 4, inhibition constant: 12400 nM
For compound 4 the middle estimate is 12-fold (1.08 log units) above the measured one; measured number outside the range, below it.
By their numbers in this assay, from the lowest: compounds 2, 4 and 1 (each within the scatter of the next). At a limit, above all of these: compound 3.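

Compound 3 stands only at a limit of the assay, not at a number: the limit of > 200000 nM in this assay, at which 1 of the 4 values shown sits. Even so, the exchange on a saturated chain carbon bound to an aromatic nitrogen counts as a large change in this assay, with an at least 16-fold lower number from compound 3 to compound 4 (1.20 log units; beyond the scatter), and the printed size is a floor with no upper end. Going by these compounds alone, the earlier step, a 1.4-fold lower number from compound 1 to compound 2 (0.14 log units; within the scatter), lay on a different chain and within the scatter, so only this new step shows that the number can respond strongly to what this place carries, here on going from carbamoylmethyl to 2-methoxyethyl.

The exchange removes the hydrogen-bond donor and the carbonyl together and adds a carbon, so this one pair cannot say which of these differences matters, and a 2-hydroxyethyl or a 2-aminoethyl chain in the same place would be needed to separate them. The compounds shown also leave open whether a longer chain such as 3-methoxypropyl, or a carboxylic acid on this chain, would lower the number further or raise it again.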